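This account rests on a few compounds, and the source may have more. Where it says the series, first, only, none or still open, it means among the compounds named here.

Compound 1 (`C=C(Br)C(=O)Nc1ccc2c(c1)/C(=C\c1ccsc1)C(=O)N2`): 2600 nM
Compound 2 (`C=C(Br)C(=O)Nc1ccc2c(c1)/C(=C\c1cccs1)C(=O)N2`): 1800 nM

Both values come from a functional assay on HeLa cells (Homo sapiens) for antiproliferative activity, read by MTT assay, with a stated time of 72 h; a lower number here means a stronger inhibitor, a higher number a weaker inhibitor. Compound 1, at 2600 nM in this assay, cannot be ranked against compound 2, since the two lie within the scatter of each other. Among the measured compounds shown here, the only measured step is a 1.4-fold lower number from compound 1 to compound 2 (0.16 log units; within the scatter) and it consists of thiophen-2-yl in place of thiophen-3-yl.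

Compound 3 (`C=C(Br)C(=O)Nc1ccc2c(c1)/C(=C/c1ccsc1)C(=O)N2`) has not yet been measured. Its relation to compound 1 is simple: the two compounds have the same atoms and bonds and differ only in configuration as drawn: 1 of 1 stereo elements differ; a double bond is drawn E in compound 1 and Z in compound 3 and so nothing leaves and nothing enters. For the measured compounds named here, the one measured step changes the thiophene attachment and leaves the double bond as drawn, so it bears on this change only indirectly. Going by the values given here, no measured pair compares an E with a Z double bond, and the data give no direction for such a change. The expectation in this assay is therefore no step beyond the scatter, held with wide uncertainty. For compound 3 the estimated value is 3000 nM with an expected range from 1000 nM to 9000 nM in this measurement. This estimate means an expected 1.2-fold higher number from compound 1 to compound 3 (0.06 log units; within the scatter) and no more.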

Compound 3, half-maximal inhibitory concentration: 3500 nM
Estimate against measurement, compound 3: 1.2-fold (0.07 log units) below, within the range that was stated.
By their numbers in this assay, from the lowest: compounds 2, 1 and 3 (each within the scatter of the next).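

In this assay, the change from an E to a Z double bond gives a 1.3-fold higher number from compound 1 to compound 3 (0.13 log units; within the scatter), the first direct reading of this change among the compounds shown. With the thiophen-3-yl group in place, the configuration as drawn therefore does not separate the two compounds beyond the usual scatter of the measurement, whereas the earlier step had varied only the thiophene attachment and had left this double bond as drawn. The reading applies to the double bond alone, with no other structural change to account for, because of one point: the fact that compounds 1 and 3 differ only in the configuration as drawn.

The compounds shown leave open whether the same holds with the thiophen-2-yl group of compound 2, since only the thiophen-3-yl compounds form an E and Z pair here. They also leave open how the number would respond to a larger change at either end of the structure, such as a phenyl ring or a carboxylic acid in place of the thiophene, or chlorine in place of the bromine on the amide side chain.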